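Anilino in place of 4-carboxyphenyl on a shared core

The source may hold more compounds than are shown below. What is called first, only, known or untested is meant among the compounds shown, and "the series" means these compounds.

Compound 1 `N#CCC(=O)N/N=C1\C(=O)Nc2ccc(S(=O)(=O)N3CCOCC3)cc21`: 302000 nM
Compound 2 `O=C1Nc2ccc(S(=O)(=O)N3CCOCC3)cc2/C1=N/c1ccc(C(=O)O)cc1`: 313000 nM

Both values come from an ADME assay on WI-38 cells (Homo sapiens) for cytotoxicity, read by sulforhodamine B assay, with a stated time of 24 h; on this read-out lower numbers stand for stronger inhibition and higher numbers for weaker inhibition. Only these two compounds have been measured so far. Compound 2, at 313000 nM, cannot be told apart from compound 1 on these numbers, since the gap between them lies within the usual scatter of repeated measurements.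

Compound 3 `O=C1Nc2ccc(S(=O)(=O)N3CCOCC3)cc2/C1=N/Nc1ccccc1` has not been measured yet. It keeps the core of compound 2 and carries anilino in place of 4-carboxyphenyl on a double-bonded nitrogen.

Within the data shown here, one measured step bears on this change, as it also exchanged the group at that place: a 1.0-fold higher number from compound 1 to compound 2 (0.02 log units; within the scatter). Putting 4-carboxyphenyl in place of ((cyanomethyl)carbonyl)amino left the number within the scatter. Among the measured compounds shown here, a single step is thin evidence, and no measurement yet shows anilino at this place. Even so, no step beyond the scatter is expected in this assay. The estimated step is a 1.1-fold lower number from compound 2 to compound 3 (0.05 log units; within the scatter). For compound 3 the expected value is 280000 nM, with an estimated range from 130000 nM to 560000 nM.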

Compound 3, half-maximal inhibitory concentration: 262000 nM
Beside the measured number, compound 3's estimate is 1.1-fold (0.03 log units) above it, within the range that was stated.
By their numbers in this assay, from the lowest: compounds 3, 1 and 2 (each within the scatter of the next).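

In this assay, putting anilino in place of 4-carboxyphenyl on a double-bonded nitrogen gives a 1.2-fold lower number from compound 2 to compound 3 (0.08 log units; within the scatter), which adds a third group at this place and a further result that cannot be told apart from the others. The same pattern holds when the change is read from the amine nitrogen, where phenyl in place of (cyanomethyl)carbonyl gives a 1.2-fold lower number from compound 1 to compound 3 (0.06 log units; within the scatter), so ((cyanomethyl)carbonyl)amino, 4-carboxyphenyl and anilino all lie within the scatter of one another, and none of the three compounds goes against this. No measurement shown here accounts for this sameness among the three groups.

As far as these compounds go, how a saturated amine such as a dimethylamino group, or a longer carbon chain, would read on this nitrogen remains open, as does any change to the shared core, which is identical in all three compounds. Every reading also comes from this assay alone, so whether these groups would stay this close together in a different cell line cannot be said from these compounds.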